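Swapping 4-cyanophenyl for 1-benzothiophen-2-yl on a sulfonamide nitrogen

The source may hold more compounds than are shown below. What is called first, only, known or untested is meant among the compounds shown, and "the series" means these compounds.

Measured so far in a physicochemical assay for lipophilicity, at pH 7.4; on this read-out lower numbers stand for lower lipophilicity and higher numbers for higher lipophilicity:
Compound 1 `CC(C)CN(c1ccc(C#N)cc1)S(=O)(=O)c1ccc2c(c1)C(=O)CC(C1CCOCC1)O2` reads 3.16
Compound 2 `CCc1ccc(N(CC2CC2)S(=O)(=O)c2ccc3c(c2)C(=O)CC(C2CCOCC2)O3)cc1` reads 3.77
Compound 3 `CCc1ccc(N(Cc2ccccc2)S(=O)(=O)c2ccc3c(c2)C(=O)CC(C2CCOCC2)O3)cc1` reads 4.84

Compound 1 stands lowest of the three, and both other compounds lie beyond the scatter above it. Compound 4 `CC(C)CN(c1cc2ccccc2s1)S(=O)(=O)c1ccc2c(c1)C(=O)CC(C1CCOCC1)O2` has not yet been measured. It differs from compound 1 in one place only, on a sulfonamide nitrogen whose other neighbours are a saturated chain carbon and the sulfonyl sulfur. The difference reads 1-benzothiophen-2-yl in place of 4-cyanophenyl on a sulfonamide nitrogen and amounts to 1-benzothiophen-2-yl in place of 4-cyanophenyl.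

Going by the values given here, no measured step touches this place. Among the compounds with values here, the only one available is a number 1.07 log units higher from compound 2 to compound 3 (beyond the scatter) and it concerns phenyl in place of cyclopropyl on a saturated chain carbon, so it bears only indirectly, as a guide to how far one swap can move the number. Compound 2 at 3.77 and compound 3 at 4.84 both lack 4-cyanophenyl and both stand above compound 1, although they also differ from it on the chain. On that evidence, a large upward step is expected in this assay and the estimated change is a number 1.24 log units higher from compound 1 to compound 4 (beyond the scatter) with considerable uncertainty. For compound 4 the estimate is 4.4 with an expected range from 3.9 to 4.9 as its upper end.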

Compound 4, distribution coefficient: 4.01
Beside the measured number, compound 4's estimate is 0.39 log units above it, within the range that was stated.
By their numbers in this assay, from the lowest: compound 1; then compounds 2 and 4 (each within the scatter of the next); then compound 3.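

In this assay, going by these compounds alone, a number 0.85 log units higher from compound 1 to compound 4 (beyond the scatter) when 1-benzothiophen-2-yl takes the place of 4-cyanophenyl on a sulfonamide nitrogen, and this is the first measured step at this position. The chain on that nitrogen and the shared core stay the same, so the step shows that changing this aromatic group alone moves the number beyond the scatter, something the gaps from compound 1 to compounds 2 and 3 could not show, as those compounds also differ on the chain. The swap removes a nitrile and adds a sulfur atom and a five-membered aromatic ring, but nothing measured here explains the step or ties it to any one of these differences.

A single pair cannot separate the loss of the nitrile from the gain of the five-membered ring, and a plain phenyl on this nitrogen would be one way to pull the two apart. As far as these compounds go, how the number responds to groups that carry a charge or a ring nitrogen here, such as a 4-carboxyphenyl or a pyridin-3-yl, also remains open.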